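A few compounds are considered here, and "the series" means these few. Any claim that something is new, unique, unknown or untested is made for them only; others in the source may bear on it.

Compound 1 `Fc1ccc(-c2nc3cnc(Nc4ccc(C(F)(F)F)cn4)cc3[nH]2)cc1F`: >= 50000 nM
Compound 2 `Fc1ccc(Nc2cc3[nH]c(-c4ccc(F)c(F)c4)nc3cn2)nc1`: >= 50000 nM
Compound 3 `Fc1ccc(Nc2cc3[nH]c(-c4ccc(F)c(C(F)(F)F)c4)nc3cn2)nc1`: >= 50000 nM

In a physicochemical assay for solubility, using the shake flask method, in simulated intestinal fluid, measured as kinetic solubility, with a stated time of 20 h, at pH 6.5 (on this read-out lower numbers stand for lower solubility and higher numbers for higher solubility), compound 2 gives >= 50000 nM, which is a limit of the assay and not a number. Compound 1 likewise sits at a limit in this assay. Compound 3 also sits at a limit in this assay. All three values sit at the limit of >= 50000 nM in this assay, at which 3 of the 3 values shown sit, so neither a step that the two limits leave unreadable from compound 1 to compound 2 nor a step that the two limits leave unreadable from compound 2 to compound 3 can be read as a size; the exchange of fluoro and trifluoromethyl on the 5-fluoropyridin-2-yl part of compound 2 leaves no trace that this assay can resolve.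

Compound 4 `O=C(O)c1ccc(Nc2cc3[nH]c(-c4ccc(F)c(F)c4)nc3cn2)nc1` differs from compound 2 by carboxy in place of fluoro on an aromatic carbon. For the measured compounds named here, no measured step touches a carboxy group, so the two unreadable steps bear on the place of the change but say nothing about its direction or size. Given that every value so far sits at the limit, compound 4 is expected to sit at the limit as well, with the step from compound 2 to compound 4 expected to read a step that the limit leaves unreadable from compound 2 to compound 4. The estimate for compound 4 in this assay is 80000 nM, in the range 30000 nM to 250000 nM.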

Compound 4, solubility: 9000 nM
The estimate for compound 4 lay 8.9-fold (0.95 log units) above the measured number, and the stated range ends above it.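

The position on the six-membered aromatic ring with 1 nitrogen, para to a large group, now gives a readable response in this assay: carboxy in place of fluoro gives an at least 5.5-fold lower number from compound 2 to compound 4 (0.74 log units; beyond the scatter), and carboxy in place of trifluoromethyl gives an at least 5.5-fold lower number from compound 1 to compound 4 (0.74 log units; beyond the scatter). The earlier steps cannot be read, so carboxy is the only group shown at this position with a number off the limit, and that number is lower. Both new steps give only a least size, because compound 1 and compound 2 stand at a limit: the limit of >= 50000 nM in this assay, at which 3 of the 4 values shown sit.

On these data alone, the true size of the change remains open. Also open, as far as these compounds go, are whether an amine, a primary amide or a methyl ester at this position gives a comparable step, and whether carboxy gives the same step with the aryl group of compound 3.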